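Tetrazole-biphenyl series: urea to tolylsulfonamide

This account rests on a few compounds, and the source may have more. Where it says the series, first, only, none or still open, it means among the compounds named here.

Measured so far:
compound 1 `CCCCc1ccc(CN(C)S(C)(=O)=O)c(=O)n1Cc1ccc(-c2ccccc2-c2nn[nH]n2)cc1` — 0.2 nM
compound 2 `CCCCc1ccc(CNC(=O)N(C)C)c(=O)n1Cc1ccc(-c2ccccc2-c2nn[nH]n2)cc1` — 2 nM

In a functional assay (aorta) for antagonist activity, with Oryctolagus cuniculus as the target (a lower number here means a stronger inhibitor, a higher number a weaker inhibitor), compound 2 gives 2 nM, the highest of the two numbers recorded; its nearest neighbour is compound 1, which in this assay gives 0.2 nM. Among the measured compounds shown here, the only step known is a 10-fold higher number from compound 1 to compound 2 (1.00 log units; beyond the scatter), a modest loss on exchanging methyl(methylsulfonyl)amino for (dimethylcarbamoyl)amino.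

Compound 3 `CCCCc1ccc(CN(C)S(=O)(=O)c2ccc(C)cc2)c(=O)n1Cc1ccc(-c2ccccc2-c2nn[nH]n2)cc1` is not yet measured. The change is methyl((4-methylphenyl)sulfonyl)amino in place of (dimethylcarbamoyl)amino on a saturated chain carbon bound to an aromatic carbon. This partly reverses the measured step, since a sulfonyl-bearing amino group with a methyl on nitrogen is present again, as in compound 1, though the entering group is larger and carries one six-membered aromatic ring of carbon only, for which no comparison exists.

Given a 10-fold higher number from compound 1 to compound 2 (1.00 log units; beyond the scatter), a return toward the number of compound 1 is expected, tempered for the untested aromatic ring: for compound 3 the estimated step is a 5.0-fold lower number from compound 2 to compound 3 (0.70 log units; beyond the scatter), a lower number beyond the scatter. Compound 3 is expected to give about 0.4 nM in this assay, within 0.1 nM to 2 nM.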

Compound 3, half-maximal inhibitory concentration: 8 nM
Beside the measured number, compound 3's estimate is 20-fold (1.30 log units) below it, and the stated range ends below it.
By their numbers in this assay, from the lowest: compound 1; then compound 2; then compound 3.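

Read in this assay, the group on the sulfonyl sulfur proves decisive at this position: the change to 4-methylphenyl gives a 40-fold higher number from compound 1 to compound 3 (1.60 log units; beyond the scatter) and is the largest step in the series, so a sulfonyl-bearing amino group with a methyl on nitrogen does not by itself preserve the low number of compound 1. The (dimethylcarbamoyl)amino group also compares favourably with the larger aromatic group, with a 4.0-fold higher number from compound 2 to compound 3 (0.60 log units; beyond the scatter) on the saturated chain carbon bound to an aromatic carbon; compound 2 therefore falls between the two sulfonyl compounds, and compound 3 goes against any reading that sulfonyl-bearing groups as a class outrank the urea of compound 2. Nothing available accounts for this ordering, and the change from methyl to 4-methylphenyl cannot be divided into the contributions of its aromatic ring and its added methyl.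

Ethyl, cyclopropyl and unsubstituted phenyl on the sulfonyl sulfur would show whether the number rises gradually or only once an aromatic ring enters. Also open, going by these compounds, is whether a hydrogen in place of the methyl on the sulfonyl-bearing nitrogen would alter the picture in either the methyl or the 4-methylphenyl sulfonyl group.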